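Shortening a Selenium-Bound Chain in Two Related Series

A few compounds are considered here, and "the series" means these few. Any claim that something is new, unique, unknown or untested is made for them only; others in the source may bear on it.

Four compounds share a selenium atom carrying a short saturated chain, set on a ring system that carries an amine. Compound 1 `CCCCC[Se]c1nc(NCc2ccccc2)c2ccccc2n1` carries a pentyl chain on its selenium and a benzylamino group on the core of compound 1. Compound 3 `C[Se]c1nc(NCc2ccccc2)c2ccccc2n1` keeps that core and differs by hydrogen in place of butyl on a saturated chain carbon bound to a selenium atom. Compound 2 `CCCCC[Se]c1nc(N)c2cccnc2n1` carries the pentyl chain and a plain amino group on a different core; the difference between the two cores is not broken down here. Compound 4 `C[Se]c1nc(N)c2cccnc2n1` is not yet measured and differs from compound 2 by hydrogen in place of butyl on a saturated chain carbon bound to a selenium atom, the same change as that from compound 1 to compound 3, made at the same place.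

In a functional assay on HT-29 cells (Homo sapiens) for cytotoxicity, read by MTT assay, with a stated time of 72 h (a higher number here means that more compound is tolerated, a lower number that less compound is tolerated), compound 1 reaches only a limit of the assay, > 100000 nM. Compound 3 likewise gives only a limit, > 100000 nM. The step that the two limits leave unreadable from compound 1 to compound 3 therefore cannot be read, because the limit of > 100000 nM in this assay, at which 2 of the 3 values shown sit, hides any difference between them. Among the measured compounds shown here, compound 2 is the only one with a number in this assay, giving 62100 nM.

For compound 4 the step is expected to be a 1.3-fold higher number from compound 2 to compound 4 (0.11 log units; within the scatter), resting on compound 2 at 62100 nM and on the unreadable step from compound 1 to compound 3, which gives no sign that the shorter chain shifts tolerance. Compound 4 is thus estimated at 80000 nM, with a range from 30000 nM to 200000 nM.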

Compound 4, concentration lethal to 50% of the cells: > 100000 nM
Compound 4: only a limit was reported; the forecaster's own chance of this, stated with the estimate: 40%; at least 1.2-fold (0.09 log units) between middle value and limit.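

In this assay compound 4 gives > 100000 nM, which is a limit of the assay and not a number. Going from the pentyl chain to the methyl group on this core therefore appears only as a floor, an at least 1.6-fold higher number from compound 2 to compound 4 (0.20 log units; that floor lies within the scatter), so the change shows no shift beyond the scatter, while the true step could still be larger than that floor. Whether the change carries from one core to the other stays unshown, because the matching step on the core of compound 1 cannot be read and this step has only a floor, and both trace back to one thing: the limit of > 100000 nM in this assay, at which 3 of the 4 values shown sit.

Among the compounds shown here, compound 2, at 62100 nM, is the only compound here with a number, so no two compounds can yet be set side by side as exact values. The compounds shown leave open whether a longer chain on the selenium atom, such as octyl, or a chain ending in a carboxylic acid would give a number on either core, which could make the effect of chain length readable.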